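The compounds below may be only part of what the source reports. "The series", "measured", "known", "first", "only" and "open" are said of these compounds alone.

Measured compounds:
- compound 1, `O=c1cc(O)c2ccc(OCc3cccc(F)c3)cc2o1`, gives 0% in an assay on isolated protein (strain Sprague-Dawley) for inhibition of Amine oxidase [flavin-containing] A (Rattus norvegicus), read by spectrophotometry, with a stated time of 5 min, tested at 10 uM; a higher number here means more inhibition at the concentration tested (going by the name of the read-out), a lower number less inhibition
- compound 2, `CCOc1cc(=O)oc2cc(OCc3cccc(F)c3)ccc12`, gives 25%
- compound 3, `CC(=O)COc1cc(=O)oc2cc(OCc3cccc(Cl)c3)ccc12`, gives 22%

Compound 3 stands second highest of the three numbers. Its nearest neighbour is compound 2, whose number is a few points higher, a gap within the usual scatter, so the two cannot be ranked. Compound 1 lies furthest away, and that gap is beyond the scatter.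

Compound 4, `CCNC(=O)Nc1cc(=O)oc2cc(OCc3cccc(Cl)c3)ccc12`, has not yet been measured. It differs from compound 3 in one place: (ethylcarbamoyl)amino in place of 2-oxopropoxy on an aromatic carbon.

Going by the values given here, only one step between measured compounds is available, a number 25 percentage points higher from compound 1 to compound 2 (beyond the scatter), which replaces a hydrogen on an oxygen with an ethyl group at the same carbon of the core. It shows that what sits at this position can move the number by a modest amount, but it does not cover an exchange of an oxygen-linked chain for a nitrogen-linked urea, nor a change in the count of hydrogen-bond donors. Among the compounds with values here, the measurements therefore give no direction for the step from compound 3 to compound 4.

Within the data shown here, with no guiding step, the expected change a number 2 percentage points lower from compound 3 to compound 4 (within the scatter) is none beyond the scatter, and compound 4 is estimated at 20%, between 0% and 50%.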

Compound 4, a percentage reported as inhibition, at one concentration (the size of the read-out at that concentration, not a potency): 0%
Compound 4: middle estimate off by 20 percentage points, on the high side, within the range that was stated.
By their numbers in this assay, from the lowest: compounds 1 and 4 (each within the scatter of the next); then compounds 3 and 2 (each within the scatter of the next).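

In this assay, exchanging 2-oxopropoxy for (ethylcarbamoyl)amino on this aromatic carbon gives a number 22 percentage points lower from compound 3 to compound 4 (beyond the scatter) and shows that a change here can also lower the number, whereas the earlier change at this carbon gave a number 25 percentage points higher from compound 1 to compound 2 (beyond the scatter) in the opposite direction. The entering group is attached through nitrogen rather than oxygen and carries hydrogen-bond donors where the leaving group has none, so this single step changes these features together and cannot assign the drop to either one. Nothing available explains why the number falls with this exchange.

The compounds shown leave open whether the nitrogen attachment alone goes with the lower number or whether the whole (ethylcarbamoyl)amino group is needed, a question that a plain amine or an acetamide on this carbon could help to separate. They also leave open how far the oxygen-linked side can be varied, for example with a longer chain or a carboxylic acid at its end, while the rest of the molecule stays the same.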